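The source may hold more compounds than are shown below. What is called first, only, known or untested is meant among the compounds shown, and "the series" means these compounds.

Working notes on the series. For the measured compounds named here, the shared core of compound 1 `N#CC1=C(N)OC(c2c[nH]c3ccccc23)=C(C#N)C1c1ccccc1F` carries an aryl group on a saturated ring carbon, and that aryl group is the only thing that changes across the set. In a functional assay, tested at 200 ug/mL (a lower number here means a weaker effect, a higher number a stronger effect of the compound at the concentration tested), compound 1 gives "not active" (no number reported). Compound 2 `N#CC1=C(N)OC(c2c[nH]c3ccccc23)=C(C#N)C1c1ccc2ccccc2c1` gives "not active" (no number reported) in this assay. Going by the values given here, compound 3 `Cc1ccccc1C1C(C#N)=C(N)OC(c2c[nH]c3ccccc23)=C1C#N` gives 21.4% in this assay; this is the only number reported among the three measured compounds, the other two entries carrying no number at all, so compound 3 stands alone as the one entry with a reported effect, and even that effect is modest.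

Compound 4 `COc1ccc(C2C(C#N)=C(N)OC(c3c[nH]c4ccccc34)=C2C#N)cc1` differs from compound 3 in one place: 4-methoxyphenyl in place of 2-methylphenyl on a saturated ring carbon. Among the compounds with values here, no measured step between two compounds differing in exactly this way exists in the set, so the size of the step from compound 3 to compound 4 in this assay cannot be read from a precedent; the two entries without a number, compound 1 and compound 2, show only that other aryl groups gave no reported effect. The step of a number 6.4 percentage points lower from compound 3 to compound 4 (within the scatter) is expected to stay within the scatter or fall slightly. Compound 4 is estimated at 15% in this assay, in a range from 0% to 32%.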

Compound 4, a percentage reported as activity, at one concentration (the size of the read-out at that concentration, not a potency): 26.4%
Beside the measured number, compound 4's estimate is 11.4 percentage points below it; the range from low to high includes it.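

The change to 4-methoxyphenyl in place of 2-methylphenyl on a saturated ring carbon gives, in this assay, a number 5 percentage points higher from compound 3 to compound 4 (within the scatter). For the compounds shown here, a reported effect at this position is therefore not confined to 2-methylphenyl: two different aryl groups now give numbers that cannot be told apart, whereas the earlier compounds offered only one number beside two entries without any. Nothing available accounts for this result or for the entries without a number.

The compounds shown leave open how a carboxylic acid or an amine on the aryl ring would read out in this assay. Also open, on these data alone, is whether a saturated group such as cyclohexyl, or a longer alkyl chain, can replace the aryl group on this carbon and keep a reported effect.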